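Series notes: amide replacement from compound 1 to compound 4

A few compounds are considered here, and "the series" means these few. Any claim that something is new, unique, unknown or untested is made for them only; others in the source may bear on it.

Measured so far in a functional assay on BXPC-3 cells (Homo sapiens) for inhibition, read by MTT assay, with a stated time of 7 days; a higher number here means a weaker inhibitor, a lower number a stronger inhibitor:
compound 1 `CCN(CC)S(=O)(=O)c1ccc(S(=O)(=O)N2CCC[C@@H](C(=O)N3CCC(F)(F)CC3)C2)cc1`: 120 nM
compound 2 `CCC(CC)S(=O)(=O)c1ccc(S(=O)(=O)N2CCC[C@@H](C(=O)N3CCC(F)(F)CC3)C2)cc1`: 40 nM
compound 3 `CCN(CC)S(=O)(=O)c1ccc(S(=O)(=O)N2CCC[C@@H](C(=O)N3CCC(C(F)F)CC3)C2)cc1`: 450 nM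

Compound 1 stands second highest of the three numbers; the nearest step is a 3.0-fold lower number from compound 1 to compound 2 (0.48 log units; beyond the scatter), the furthest a 3.8-fold higher number from compound 1 to compound 3 (0.57 log units; beyond the scatter). Compound 4 `CCN(CC)S(=O)(=O)c1ccc(S(=O)(=O)N2CCC[C@@H](C(=O)NC3CCOCC3)C2)cc1` is not yet measured. It differs from compound 1 at the carbonyl carbon: (oxan-4-yl)amino in place of 4,4-difluoropiperidin-1-yl on a carbonyl carbon. Of the measured steps, only a 3.8-fold higher number from compound 1 to compound 3 (0.57 log units; beyond the scatter) touches the same place, and that change still kept a piperidinyl group on the carbonyl carbon. The exchange in compound 4 goes further than that, so a weaker inhibitor is expected, with a step of about a 3.8-fold higher number from compound 1 to compound 4 (0.57 log units; beyond the scatter). Compound 4 is therefore estimated at 450 nM in this assay, within 150 nM to 1500 nM.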

Compound 4, half-maximal inhibitory concentration: 8570 nM
For compound 4 the middle estimate is 19-fold (1.28 log units) below the measured one; the whole stated range lies below it.
By their numbers in this assay, from the lowest: compound 2; then compound 1; then compound 3; then compound 4.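

In this assay, the carbonyl carbon proves far less forgiving than the change within the piperidinyl groups suggested: a 71-fold higher number from compound 1 to compound 4 (1.85 log units; beyond the scatter) is a large loss and a 19-fold higher number from compound 3 to compound 4 (1.28 log units; beyond the scatter) is also large. In this change, (oxan-4-yl)amino brings a hydrogen-bond donor and a ring oxygen together, and the compounds cannot separate their contributions. Nothing available explains the loss.

Morpholin-4-yl, which keeps the ring oxygen without the amide hydrogen, and cyclohexylamino, which keeps the amide hydrogen without the ring oxygen, would separate the two on this carbonyl carbon. Going by these compounds, whether pentan-3-yl on the sulfonyl sulfur would offset this loss also remains open.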